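Imidazole to imidazoline on a thioether: one small swap

This account rests on a few compounds, and the source may have more. Where it says the series, first, only, none or still open, it means among the compounds named here.

Measured compounds:
- compound 1, `Clc1ccc2[nH]c(SCc3ccccc3CCc3ccccc3)nc2c1`, gives 47% in an assay on isolated protein for inhibition of Indoleamine 2,3-dioxygenase 1 (Homo sapiens), with a stated time of 60 min, tested at 10 uM; a higher number here means more inhibition at the concentration tested (going by the name of the read-out), a lower number less inhibition
- compound 2, `c1ccc(CCc2ccccc2CSc2ncc[nH]2)cc1`, gives 19% in this assay

Of the two numbers at hand, compound 2 is the lower one; compound 1 sits clearly higher, and the gap between them is beyond the usual scatter. Compound 3, `c1ccc(CCc2ccccc2CSC2=NCCN2)cc1`, is the untested partner of compound 2. The two differ in a single place: a group of 5 heavy atoms (3 carbon, 2 nitrogen; one five-membered non-aromatic ring with 2 hetero atoms) in place of a group of 5 heavy atoms (3 carbon, 2 nitrogen; one five-membered aromatic ring with 2 hetero atoms), on a sulfur. For the measured compounds named here, nothing measured yet shows what such a swap does in this assay, so there is no step to lean on. Without that guidance the expected step of a number 1 percentage points lower from compound 2 to compound 3 (within the scatter) is small and in no fixed direction, most likely staying within the scatter. Compound 3 is therefore estimated at 18%, with a range from 5% to 35%.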

Compound 3, a percentage reported as inhibition, at one concentration (the size of the read-out at that concentration, not a potency): 17%
Compound 3: middle estimate off by 1 percentage points, on the high side; the measured number falls inside the stated range.
By their numbers in this assay, from the lowest: compounds 3 and 2 (each within the scatter of the next); then compound 1.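

In this assay, for the compounds shown here, replacing the 1H-imidazol-2-yl group on the sulfur with its non-aromatic five-membered counterpart gives a number 2 percentage points lower from compound 2 to compound 3 (within the scatter), the first reading of this change. At this one tested concentration, giving up the aromatic ring for a ring with a double bond and the additional acceptor counted for it makes no difference that can be read, so the two groups cannot be told apart here. No measurement at hand explains why the two compounds read alike.

Compound 1 gives 47% in this assay, so the group on the sulfur can matter, but these compounds do not show which of its features count. On these data alone, it also remains open how a pyridine or a 1,2,4-triazole ring would read on the same sulfur.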